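A few compounds are considered here, and "the series" means these few. Any claim that something is new, unique, unknown or untested is made for them only; others in the source may bear on it.

Compound 2 `Cc1cccc(N2CCN(C(=O)C(C)N3C(=O)CCC3=O)CC2)c1` stands level with compound 1 `CC(C(=O)N1CCN(c2ccccc2F)CC1)N1C(=O)CCC1=O` in a functional assay on the whole organism (strain Swiss) with Mus musculus as the target, in the maximal electroshock model, with a stated time of 0.5 h, at a dose of 100 mg/kg by the intraperitoneal route; a higher number here means a stronger effect of the compound at the dose given, a lower number a weaker effect: compound 1 gives 0%, and compound 2 gives 0%, so no change at the digits printed from compound 1 to compound 2 (within the scatter). Compound 3 `CC(C(=O)N1CCN(c2cccc(Cl)c2)CC1)N1C(=O)CCC1=O` differs from compound 2 by chloro in place of methyl on an aromatic carbon. Among the compounds with values here, only one measured step bears on it, the change of the aryl group on the amine nitrogen in the ring from compound 1 to compound 2, which left the read-out unchanged within the scatter. Within the data shown here, with both anchors at the floor and no step of any size among the measured compounds, the expected step from compound 2 to compound 3 is no change at the digits printed from compound 2 to compound 3 (within the scatter). Compound 3 is therefore expected to give 0%, in the range 0% to 15%.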

Compound 3, a percentage reported as activity, at one dose (the size of the read-out at that dose, not a potency): 75%
Compound 3: middle estimate off by 75 percentage points, on the low side, and the stated range ends below it.
By their numbers in this assay, from the lowest: compounds 1 and 2 (each within the scatter of the next); then compound 3.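

Chloro in place of methyl on an aromatic carbon, meta to a large group, gives a number 75 percentage points higher from compound 2 to compound 3 (beyond the scatter) in this assay, so a change of one heavy atom on this aryl group can lift the read-out off the floor shared by compound 1 and compound 2. The 3-chlorophenyl group also stands clear of the 2-fluorophenyl group, with a number 75 percentage points higher from compound 1 to compound 3 (beyond the scatter). Nothing available gives a reason for this gain.

Open, on these data alone, is whether bromo, trifluoromethyl or methoxy at this place would keep the effect, and whether chloro on another aromatic carbon of the ring would do the same. A read-out at one dose shows the stronger effect of compound 3 at that dose only and leaves open how the effect would change at other doses.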